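Amine substituent variation on the shared core

The compounds below may be only part of what the source reports. "The series", "measured", "known", "first", "only" and "open" are said of these compounds alone.

The series keeps one core and varies the group on the nitrogen bound to the aromatic ring. Compound 1 `CNc1cc(Oc2ccc(NC(=O)Nc3cccc(C(F)(F)F)c3)cc2)ncn1` gives 40 nM in an assay on isolated protein for inhibition of serine/threonine-protein kinase TNNI3K (Homo sapiens); on this read-out higher numbers stand for weaker inhibition and lower numbers for stronger inhibition. Compound 2 `CC(C)Nc1cc(Oc2ccc(NC(=O)Nc3cccc(C(F)(F)F)c3)cc2)ncn1` gives 40 nM in this assay, and compound 3 `CC(C)(O)CNc1cc(Oc2ccc(NC(=O)Nc3cccc(C(F)(F)F)c3)cc2)ncn1` gives 40 nM in this assay. The step of no change at the digits printed from compound 1 to compound 2 (within the scatter) and the step of no change at the digits printed from compound 1 to compound 3 (within the scatter) both stay within the scatter, as does no change at the digits printed from compound 2 to compound 3 (within the scatter). On these numbers compound 3 stands level with compound 1 and compound 2 in this assay; none of the three can be set apart from the others.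

Compound 4 `CCNc1cc(Oc2ccc(NC(=O)Nc3cccc(C(F)(F)F)c3)cc2)ncn1` is the next member and has not been measured. It differs from compound 3 as methyl in place of 1-hydroxy-1-methylethyl on a saturated chain carbon bound to a nitrogen on an aromatic ring. The same difference, cut one bond further out, reads 2-hydroxy-2-methylpropyl to ethyl. Going by the values given here, the steps that bear on it are those among compounds 1, 2 and 3, since each changes the same group on the nitrogen on the aromatic ring, and each was within the scatter. Methyl, isopropyl and 2-hydroxy-2-methylpropyl at this place all give the same reading, so the ethyl of compound 4 is expected to behave alike, with no change at the digits printed from compound 3 to compound 4 (within the scatter) as the expected step and no change beyond the scatter. In this assay compound 4 is accordingly estimated at 40 nM, within 20 nM to 80 nM.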

Compound 4, half-maximal inhibitory concentration: 25 nM
Compound 4: the middle estimate sits 1.6-fold (0.20 log units) above what was measured; the measured number falls inside the stated range.
By their numbers in this assay, from the lowest: compounds 4, 1, 2 and 3 (each within the scatter of the next).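

In this assay, ethyl joins methyl, isopropyl and 2-hydroxy-2-methylpropyl among the groups on the nitrogen on the aromatic ring that cannot be told apart, with methyl to ethyl (a 1.6-fold lower number from compound 1 to compound 4 (0.20 log units; within the scatter)) and isopropyl to ethyl (a 1.6-fold lower number from compound 2 to compound 4 (0.20 log units; within the scatter)) both lying within the scatter. Removing the 1-hydroxy-1-methylethyl, with its hydrogen-bond donor and hydrogen-bond acceptor, also stays within the scatter (a 1.6-fold lower number from compound 3 to compound 4 (0.20 log units; within the scatter)), so all four substituents shown on this nitrogen are accommodated in this assay without a separable difference. Nothing available bears on why these groups read alike.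

The substituents shown are limited to three small alkyl groups and one hydroxyl-bearing chain, so it remains open whether a longer chain, a cyclopropyl ring, a morpholine ring or a carboxylic acid at the end of the chain would take the reading beyond the scatter. The compounds also leave open whether the free amino group, with hydrogen on the nitrogen in place of any carbon substituent, would hold the same level, and whether this flat response would persist if the trifluoromethyl group were replaced by another group.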